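A Methoxy Added Where Compound 2 Shows No Inhibition

The source may report more compounds than this note shows. Statements on the series, on what has been measured and on what is new or still open speak of the compounds shown alone.

Two measured compounds share one core and differ only in the part hanging from the sulfur-bearing chain. Compound 1 `CC1=CC[C@H](C(C)(C)NC(=S)N/N=C/c2cccs2)CC1` gives, in a functional assay on UACC-62 cells (Homo sapiens) for inhibition, read by sulforhodamine B assay, with a stated time of 48 h (on this read-out higher numbers stand for weaker inhibition of growth and lower numbers for stronger inhibition of growth), a value of 2600 nM. For compound 2 `CC1=CC[C@H](C(C)(C)NC(=S)N/N=C(\C)c2ccccc2)CC1` this assay reports no number, only a limit, > 100000 nM. Compound 2 is thus the one that sits at the limit of > 100000 nM in this assay, at which 1 of the 2 values shown sits. Nothing links these two as a single step, so the two values are simply what they are.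

The next compound, compound 3 `COc1ccc(/C(C)=N/NC(=S)NC(C)(C)[C@H]2CC=C(C)CC2)cc1`, differs from compound 2 by methoxy in place of hydrogen on an aromatic carbon. With compound 2 giving only a limit, a change this small is expected to move the result little or not at all beyond the scatter, and the step of a number no higher from compound 2 to compound 3 (the limit leaves the size open) is estimated to be about nothing. Compound 3 is therefore expected to give roughly 100000 nM, within a range from 30000 nM to 300000 nM.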

Compound 3, concentration for 50% growth inhibition: 95300 nM
Beside the measured number, compound 3's estimate is 1.0-fold (0.02 log units) above it; measured number inside the range.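

The change from phenyl to 4-methoxyphenyl, with the methoxy para to a large group, gives an at least 1.0-fold lower number from compound 2 to compound 3 (0.02 log units; that floor lies within the scatter). In this assay compound 3 gives a real number, 95300 nM, so this position now has one measured reading, and that reading shows no clear gain from methoxy. Compound 2 rests on a limit and not on a number: the limit of > 100000 nM in this assay, at which 1 of the 3 values shown sits.

As far as these compounds go, the true size of the step stays open, with only its floor known, so even a small effect of methoxy cannot be told from none. Also open, from the compounds shown here alone, is what a different group at this same position would do, such as an amine, a hydroxyl or a chlorine atom, and whether any of them would bring the number closer to that of compound 1, 2600 nM.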